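Demethylation of the aryl methoxy group in the pyrazole series

This account rests on a few compounds, and the source may have more. Where it says the series, first, only, none or still open, it means among the compounds named here.

Of the compounds shown here, two have been measured in a functional assay on SF-295 cells (Homo sapiens) for inhibition, read by sulforhodamine B assay, with a stated time of 48 h; on this read-out lower numbers stand for stronger inhibition of growth and higher numbers for weaker inhibition of growth. Compound 2 `COc1cc(C)cc(-c2nn(CC#N)cc2-c2ccnc(-c3ccc(N(C)C)cc3)c2)c1` gives 1910 nM. Compound 1 `Cc1cc(O)cc(-c2nn(CC#N)cc2-c2ccnc(-c3ccc(Oc4ccccc4)cc3)c2)c1` gives 21200 nM. Compound 2 therefore stands at the lower of the two numbers, and the gap to compound 1 lies beyond the scatter; since the two differ at two places, neither place can be credited with the gap on its own.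

Compound 3 `Cc1cc(O)cc(-c2nn(CC#N)cc2-c2ccnc(-c3ccc(N(C)C)cc3)c2)c1` is not yet measured. It differs from compound 2 in one place only: hydrogen in place of methyl on an oxygen on an aromatic ring. The other substituent of compound 2, the dimethylamino group, is retained.

Among the compounds with values here, no pair of measured compounds differing in a single place exists here, so no measured step guides the expectation for this change. The hydroxy group is also present in compound 1, but there it is combined with a phenoxy group, so its own contribution cannot be separated from the value of 21200 nM. The expected step from compound 2 to compound 3 is therefore a 1.6-fold higher number from compound 2 to compound 3 (0.20 log units; within the scatter), close to none beyond the scatter, with a slight lean toward weaker inhibition of growth. Compound 3 is estimated at 3000 nM, within a range of 1000 nM to 12000 nM.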

Compound 3, concentration for total growth inhibition: 8710 nM
The estimate for compound 3 lay 2.9-fold (0.46 log units) below the measured number, and the stated range covers the measured number.
By their numbers in this assay, from the lowest: compound 2; then compound 3; then compound 1.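

In this assay, within the data shown here, the change from methoxy to hydroxy on the 3-methoxy-5-methylphenyl group, with the dimethylamino group kept, gives a 4.6-fold higher number from compound 2 to compound 3 (0.66 log units; beyond the scatter) and so provides the first single-place reading at this oxygen, with the methoxy form of the pair giving the stronger inhibition of growth. Compound 3 also opens the second place to reading: with the hydroxy group kept, dimethylamino in place of phenoxy on an aromatic carbon gives a 2.4-fold lower number from compound 1 to compound 3 (0.39 log units; beyond the scatter). The gap between compound 1 and compound 2 therefore no longer rests on a single unresolved comparison, as each of the two places carries a step beyond the scatter. No measurement available here accounts for either step.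

On these data alone, whether a longer chain on this oxygen, such as ethoxy, or an amine in place of the hydroxy group would stand nearer compound 2 or compound 3 remains open. Also open is the size of the step at the oxygen when phenoxy replaces dimethylamino, as the compounds shown hold that exchange only in the hydroxy form.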